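The source may hold more compounds than are shown below. What is called first, only, known or untested is meant among the compounds shown, and "the series" means these compounds.

Series notes, two measured members and one pending. Compound 1 `O=C(NCc1ccc(S(=O)(=O)c2ccccc2)cc1)NCc1cccnc1` was measured in an assay on isolated protein for inhibition of Nicotinamide phosphoribosyltransferase (Homo sapiens), read by mass spectrometry, with stated times of 15 min and 30 min (a lower number here means a stronger inhibitor, a higher number a weaker inhibitor), and compound 1 gives 19 nM. Compound 2 `O=C(NCc1ccc(S(=O)(=O)c2cncc(C(F)(F)F)c2)cc1)N1Cc2ccncc2C1` in this assay gives 15 nM. On the numbers shown compound 2 has the lower of the two values, but its gap to compound 1 lies within the scatter, so the two are not ordered by these data. Compound 3 `CCCn1cc(S(=O)(=O)c2ccc(CNC(=O)N3Cc4ccncc4C3)cc2)cn1` differs from compound 2 by 1-propyl-1H-pyrazol-4-yl in place of 5-(trifluoromethyl)pyridin-3-yl on a sulfonyl sulfur. Among the measured compounds shown here, no step between measured compounds touches this part of the molecule, so nothing sizes the change; the two measured values simply sit close together. The step from compound 2 to compound 3 is expected to be a 1.7-fold higher number from compound 2 to compound 3 (0.22 log units; within the scatter), no further than the scatter in either direction. Compound 3 is expected to give about 25 nM in this assay, with a range of 8 nM to 80 nM.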

Compound 3, half-maximal inhibitory concentration: 17 nM
For compound 3 the middle estimate is 1.5-fold (0.17 log units) above the measured one; the range from low to high includes it.
By their numbers in this assay, from the lowest: compounds 2, 3 and 1 (each within the scatter of the next).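

Among the compounds shown here, on the sulfonyl sulfur, the replacement of 5-(trifluoromethyl)pyridin-3-yl by 1-propyl-1H-pyrazol-4-yl gives the first sized step at this position: a 1.1-fold higher number from compound 2 to compound 3 (0.05 log units; within the scatter) in this assay on the shared core. For this pair, a five-membered aromatic ring with 2 hetero atoms and a six-membered aromatic ring with 1 hetero atom are not separated by this read-out, even with the propyl chain present on the former. No supporting measurement is available to explain this result.

The compounds shown leave open whether the propyl chain contributes, which a methyl group or an unsubstituted pyrazole at the same place would test. Also open, on these data alone, is how the position responds to a carboxylic acid or an amine at the end of that chain, or to a simple alkyl chain directly on the sulfonyl sulfur.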